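This account rests on a few compounds, and the source may have more. Where it says the series, first, only, none or still open, it means among the compounds named here.

Of the compounds shown here, two built on a shared core have been measured in an assay for inhibition of hexokinase-1 (Homo sapiens), read by ADP-Glo, with a stated time of 45 min, in the presence of a further agent that is not named here; a lower number here means a stronger inhibitor, a higher number a weaker inhibitor. Compound 1 `O=C(N[C@H]1C(O)O[C@H](CO)[C@@H](O)[C@@H]1O)c1cccc(-c2ccccc2)c1` gives 790 nM. Compound 2 `O=C(O)c1cccc(S(=O)(=O)NC[C@H]2OC(O)[C@H](NC(=O)c3cccc(-c4ccccc4)c3)[C@@H](O)[C@@H]2O)c1`, which carries a sulfonamide chain on the core, gives 25 nM. Compound 2 stands at the lower of the two numbers, and its gap to compound 1 lies well beyond the scatter. Compound 3 `O=C(N[C@H]1C(O)O[C@H](CNS(=O)(=O)c2cnccc2Cl)[C@@H](O)[C@@H]1O)c1cccc(-c2ccccc2)c1` has not yet been measured in this assay . It differs from compound 2 in one place: 4-chloropyridin-3-yl in place of 3-carboxyphenyl on a sulfonyl sulfur. For the measured compounds named here, no step between measured compounds covers a change of this kind, so any expectation rests on the two numbers alone. Going by the values given here, a step of moderate size toward a higher number is expected, a 2.4-fold higher number from compound 2 to compound 3 (0.38 log units; beyond the scatter), since the only guide is that compound 2 sits at 25 nM while the plainer compound 1 sits much higher. Compound 3 is therefore estimated at 60 nM, within a range from 15 nM to 250 nM.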

Compound 3, half-maximal inhibitory concentration: 20 nM
The estimate for compound 3 lay 3.0-fold (0.48 log units) above the measured number; the measured number falls inside the stated range.
By their numbers in this assay, from the lowest: compounds 3 and 2 (each within the scatter of the next); then compound 1.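

In this assay the change on the sulfonyl sulfur gives a 1.3-fold lower number from compound 2 to compound 3 (0.10 log units; within the scatter), so 4-chloropyridin-3-yl and 3-carboxyphenyl cannot be told apart at this position, although the swap removes the carboxylic acid and the ring of carbon only. The step of a 40-fold lower number from compound 1 to compound 3 (1.60 log units; beyond the scatter), with a group of 11 heavy atoms in place of one oxygen atom, shows that a large step from compound 1 does not require the 3-carboxyphenyl group. No measurement is available that would explain why these two groups read alike.

The compounds shown do not separate the part played by the ring nitrogen from that of the chlorine in 4-chloropyridin-3-yl. They also leave open how a plain phenyl ring, a methyl group or an amine on the sulfonyl sulfur would read.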